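The source may report more compounds than this note shows. Statements on the series, on what has been measured and on what is new or still open speak of the compounds shown alone.

Measured in a functional assay on KBVIN cells (Homo sapiens) for antiproliferative activity, read by sulforhodamine B assay, with a stated time of 3 days; a lower number here means that less compound is needed, a higher number that more compound is needed for the effect:
- compound 1 `CCC1=C(O)c2c(oc(-c3ccccc3C)cc2=O)C(CC)(CC)C1=O`: 2.41 uM
- compound 2 `CCC1=C(O)c2c(oc(-c3ccc(C)c(C)c3)cc2=O)C(CC)(CC)C1=O`: 0.71 uM

Of the two numbers, compound 2 has the lower, at 0.71 uM. Compound 3 `CCC1=C(O)c2c(oc(-c3ccc(C)c(F)c3)cc2=O)C(CC)(CC)C1=O` carries fluoro in place of methyl on an aromatic carbon, ortho to a methyl group and meta to a large group: fluoro in place of methyl on an aromatic carbon. The same difference reads 3,4-dimethylphenyl to 3-fluoro-4-methylphenyl.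

Going by the values given here, only one measured step bears on this group: a 3.4-fold lower number from compound 1 to compound 2 (0.53 log units; beyond the scatter), modest and beyond the scatter, for 3,4-dimethylphenyl in place of 2-methylphenyl. Among the compounds with values here, it is not the same exchange, and no measured pair swaps methyl for fluoro, so it offers only a loose guide to size. A small move toward a higher number is expected in this assay, possibly no move beyond the scatter. The estimated step is a 1.4-fold higher number from compound 2 to compound 3 (0.15 log units; within the scatter). For compound 3 the expected value is 1 uM, with an expected range of 0.4 uM to 2.5 uM.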

Compound 3, concentration for half-maximal effect: 2.95 uM
Compound 3: the middle estimate sits 3.0-fold (0.47 log units) below what was measured, outside the stated range (above it).
By their numbers in this assay, from the lowest: compound 2; then compounds 1 and 3 (each within the scatter of the next).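

Replacing methyl with fluoro on this aromatic carbon, ortho to a methyl group and meta to a large group, is not a neutral exchange in this assay, giving a 4.2-fold higher number from compound 2 to compound 3 (0.62 log units; beyond the scatter). The advantage of the 3,4-dimethylphenyl group does not carry over to 3-fluoro-4-methylphenyl, which leaves no separation from the 2-methylphenyl group, with a 1.2-fold higher number from compound 1 to compound 3 (0.09 log units; within the scatter). No measurement at hand accounts for the difference between methyl and fluoro here.

On these data alone, whether methyl is specifically favoured at this carbon stays open, since a chloro, ethyl or methoxy group there would show how narrow the preference is. Also open, as far as these compounds go, is whether the same exchange has a similar effect when the 4-methyl group is replaced, for example by hydrogen or chloro.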